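Benzoxazole sulfonamide series: removing the ring fluorine

The source may hold more compounds than are shown below. What is called first, only, known or untested is meant among the compounds shown, and "the series" means these compounds.

Measured so far, in an assay on cells for inhibition of HSP60/HSP10 (Homo sapiens), with a stated time of 60 min; a lower number here means a stronger inhibitor, a higher number a weaker inhibitor:
- compound 1, `O=S(=O)(Nc1ccc(-c2nc3ccccc3o2)cc1)c1cccc(F)c1`, 71000 nM
- compound 2, `O=S(=O)(Nc1ccc(-c2nc3ccccc3o2)cc1)c1cccc(O)c1`, 62000 nM
- compound 3, `O=S(=O)(Nc1ccc(-c2nc3ccccc3o2)cc1)c1ccc(F)c(C(F)(F)F)c1`, 28000 nM

Compound 3 gives the lowest number of the three; its nearest neighbour is compound 2, and both compound 2 and compound 1 sit beyond the scatter above it. Within the data shown here, the one single-point step measured, a 1.1-fold lower number from compound 1 to compound 2 (0.06 log units; within the scatter), is within the scatter, so hydroxy in place of fluoro on an aromatic carbon of the sulfonyl-bearing ring changes nothing that can be read. Among the measured compounds shown here, compound 3 differs from compound 1 in two places, so the two values show only that compound 3 comes out stronger.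

Compound 4, `O=S(=O)(Nc1ccc(-c2nc3ccccc3o2)cc1)c1cccc(C(F)(F)F)c1`, follows from compound 3 by hydrogen in place of fluoro on an aromatic carbon, ortho to a trifluoromethyl group and para to a large group. For the measured compounds named here, no measured step removes a fluoro, and the only step touching that ring is within the scatter, so nothing here points to a change in this assay beyond the scatter. The step of a 1.3-fold higher number from compound 3 to compound 4 (0.10 log units; within the scatter) is thus expected to be small. Compound 4 is expected at 35000 nM, in the range 15000 nM to 85000 nM.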

Compound 4, half-maximal inhibitory concentration: 57000 nM
The estimate for compound 4 lay 1.6-fold (0.21 log units) below the measured number; the range from low to high includes it.
By their numbers in this assay, from the lowest: compound 3; then compounds 4, 2 and 1 (each within the scatter of the next).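

In this assay, among these compounds, the position ortho to a trifluoromethyl group and para to a large group is the first place where a single change moves the number beyond the scatter: hydrogen in place of fluoro gives a 2.0-fold higher number from compound 3 to compound 4 (0.31 log units; beyond the scatter) and is a modest step. Once that fluoro is gone, the other changes on this ring give no readable difference, since trifluoromethyl in place of hydroxy (a 1.1-fold lower number from compound 2 to compound 4 (0.04 log units; within the scatter)) and trifluoromethyl in place of fluoro (a 1.2-fold lower number from compound 1 to compound 4 (0.10 log units; within the scatter)) both stay within the scatter, so trifluoromethyl alone does not separate these compounds and the fluoro of compound 3 is what sets it apart. No supporting data bear on why this step occurs.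

Still open, as far as these compounds go, is whether the step is specific to fluoro or would also appear with another group at this position, such as chloro, an amine or a carboxylic acid. Also open, from the compounds shown here alone, is whether it depends on the trifluoromethyl group present in both compound 3 and compound 4, which a methyl or a longer chain in its place would test.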